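This account rests on a few compounds, and the source may have more. Where it says the series, first, only, none or still open, it means among the compounds named here.

Going by the values given here, compound 2, `O=C(NC/C=C\Cn1ccc(=O)[nH]c1=O)c1ccc(F)cc1`, is the only compound here with a numerical result: in a functional assay on MCF7 cells (Homo sapiens) for cytotoxicity, read by MTT assay, with a stated time of 72 h (a lower number here means a stronger inhibitor, a higher number a weaker inhibitor), compound 2 gives 2700 nM. Compound 1, `Cc1cn(C/C=C\CNC(=O)c2ccccc2)c(=O)[nH]c1=O`, reaches only a limit of the assay rather than a number, and in this assay compound 1 gives > 100000 nM. Among the compounds with values here, no two measured compounds differ in a single place, so no measured step is available; the one piece of evidence is the limit of > 100000 nM in this assay, at which 1 of the 2 values shown sits. Compound 3, `Cc1cn(C/C=C\CNC(=O)c2ccc(F)cc2)c(=O)[nH]c1=O`, differs from compound 2 by methyl in place of hydrogen on an aromatic carbon. Compound 1 also carries this methyl, and its result in this assay is only a limit. The step of a 7.4-fold higher number from compound 2 to compound 3 (0.87 log units; beyond the scatter) is therefore expected to be a loss of potency beyond the usual scatter, though with much uncertainty. For compound 3 the estimate in this assay is 20000 nM, within a range from 3000 nM to 100000 nM.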

Compound 3, half-maximal inhibitory concentration: 24100 nM
Compound 3: the middle estimate sits 1.2-fold (0.08 log units) below what was measured; low and high end bracket the measured number.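

In this assay, the methyl in place of hydrogen on an aromatic carbon now has a measured size rather than an inference from a limit, and it costs potency beyond the scatter (an 8.9-fold higher number from compound 2 to compound 3 (0.95 log units; beyond the scatter)). With that methyl present, swapping a hydrogen for fluoro also gives a step beyond the scatter, the first sign that this second place matters too (an at least 4.1-fold lower number from compound 1 to compound 3 (0.61 log units; beyond the scatter)). That step has only a lower bound: in this assay compound 1 gives > 100000 nM, which is a limit of the assay and not a number.

From the compounds shown here alone, whether an ethyl group, an amine or a chlorine at the methyl's place would behave as the methyl does remains open. Going by these compounds, the size of the fluoro step on a core without the methyl is also open.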